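Chloro for Fluoro in a Lipoxygenase Inhibitor Pair

This account rests on a few compounds, and the source may have more. Where it says the series, first, only, none or still open, it means among the compounds named here.

Measured compounds:
Compound 1 `C[C@H](C#Cc1cccc(C(=O)NCC[C@H](c2ccc(F)cc2)c2ccc(C(F)(F)F)cc2)c1)N(O)C(N)=O`: 230 nM
Compound 2 `CC(C#Cc1cccc(C(=O)NCCC(c2ccccc2)c2ccc(F)cc2)c1)N(O)C(N)=O`: 160 nM

Of the compounds shown here, two have been measured in an assay for inhibition of Polyunsaturated fatty acid 5-lipoxygenase (Homo sapiens), read by HPLC, with stated times of 15 min and 10 min; on this read-out lower numbers stand for stronger inhibition and higher numbers for weaker inhibition. Compound 1 gives 230 nM, and compound 2 gives 160 nM. Compound 2 has the lower of the two numbers, but its difference from compound 1 lies within the usual scatter, so the two cannot be told apart. Compound 3 `CC(C#Cc1cccc(C(=O)NCCC(c2ccccc2)c2ccc(Cl)cc2)c1)N(O)C(N)=O` has not yet been measured. It differs from compound 2 by chloro in place of fluoro on an aromatic carbon. No comparison of this kind exists among the measured compounds, so the expected step in this assay is a 1.1-fold lower number from compound 2 to compound 3 (0.03 log units; within the scatter), nothing beyond the scatter. Compound 3 is expected to give 150 nM in this assay, with a range from 70 nM to 350 nM.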

Compound 3, half-maximal inhibitory concentration: 120 nM
The estimate for compound 3 lay 1.3-fold (0.10 log units) above the measured number; the measured number falls inside the stated range.
By their numbers in this assay, from the lowest: compounds 3, 2 and 1 (each within the scatter of the next).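

Swapping 4-fluorophenyl for 4-chlorophenyl gives a 1.3-fold lower number from compound 2 to compound 3 (0.12 log units; within the scatter) in this assay, the first comparison at this aromatic carbon, para to a large group. Compound 3 and compound 2 cannot be told apart, so on these numbers the position holds chloro as well as it holds fluoro. Nothing available bears on why the two read alike.

The compounds shown leave open how this position would respond to a group other than these halogens, such as bromo, methoxy, an amine or a carboxylic acid.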